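Chloromethyl for Carboxy on an Oxazole Ketone Chain

The source may report more compounds than this note shows. Statements on the series, on what has been measured and on what is new or still open speak of the compounds shown alone.

Measured compounds:
compound 1 `CCOS(=O)(=O)/C=C/c1ccc(-c2cnc(C(=O)CCCCCCc3ccccc3)o2)nc1`, 2.1 nM
compound 2 `O=C(O)CCCCc1cnc(C(=O)CCCCCCc2ccccc2)o1`, 23.8 nM
compound 3 `O=CCCCCc1cnc(C(=O)CCCCCCc2ccccc2)o1`, 14.6 nM

Compound 1, compound 2 and compound 3 share a core and differ only in the group carried on the side chain. In an assay for inhibition of Fatty-acid amide hydrolase 1 (Rattus norvegicus), using a Dixon plot (on this read-out higher numbers stand for weaker inhibition and lower numbers for stronger inhibition), compound 2 gives 23.8 nM, the highest of the three numbers; compound 3 stands nearest to it, and compound 1 furthest away, beyond the scatter.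

Compound 4 `O=C(CCCCCCc1ccccc1)c1ncc(CCCCCCl)o1` is not yet measured. It differs from compound 2 in one place: chloromethyl in place of carboxy on a saturated chain carbon, four bonds along the chain from an aromatic carbon. Going by the values given here, the only measured step that bears on this change is the one from compound 2 to compound 3, where the chain end loses its donor: a 1.6-fold lower number from compound 2 to compound 3 (0.21 log units; within the scatter). That step stayed within the scatter, so removing the donor alone did not move the number much. Compound 4 goes further, removing both donor and acceptor, and nothing measured here covers a chloromethyl end. On this basis the step from compound 2 to compound 4 in this assay is expected to be small to modest, toward a lower number, a 2.4-fold lower number from compound 2 to compound 4 (0.38 log units; beyond the scatter). Compound 4 is therefore estimated at 10 nM, with a range from 3 nM to 35 nM.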

Compound 4, inhibition constant: 5.2 nM
For compound 4 the middle estimate is 1.9-fold (0.28 log units) above the measured one, and the stated range covers the measured number.
By their numbers in this assay, from the lowest: compound 1; then compound 4; then compounds 3 and 2 (each within the scatter of the next).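

The chain end can move the number beyond the scatter: in this assay, chloromethyl in place of carboxy gives a 4.6-fold lower number from compound 2 to compound 4 (0.66 log units; beyond the scatter), whereas the earlier exchange of hydroxy for hydrogen on the carbonyl carbon stayed within the scatter. Chloromethyl in place of formyl at the same place points the same way, with a 2.8-fold lower number from compound 3 to compound 4 (0.45 log units; beyond the scatter), so this end, with no hydrogen-bond donor or acceptor, gives a lower number than either oxygen-bearing end. Nothing available explains this difference.

As far as these compounds go, it remains open whether the chlorine itself matters, which a methyl, bromomethyl or nitrile end could test. Also open, from the compounds shown here alone, is whether the gain would hold on a longer chain ending in chloromethyl, or how a chloromethyl end would compare with the group carried by compound 1.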